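Benzylic aryl swap on a shared sulfonamide chain

The source may report more compounds than this note shows. Statements on the series, on what has been measured and on what is new or still open speak of the compounds shown alone.

Measured compounds, with their numbers in a functional assay on HPAC cells (Homo sapiens) for inhibition, read by MTT assay, with a stated time of 72 h; a lower number here means a stronger inhibitor of growth, a higher number a weaker inhibitor of growth:
compound 1 `O=S(=O)(NCCCNCc1ccc(Cl)c(Cl)c1)c1cc(C(F)(F)F)cc(C(F)(F)F)c1` gives 2500 nM
compound 2 `O=S(=O)(NCCCNCC1COc2ccccc2O1)c1cc(C(F)(F)F)cc(C(F)(F)F)c1` gives 2700 nM
compound 3 `COc1cccc(CNCCCNS(=O)(=O)c2cc(C(F)(F)F)cc(C(F)(F)F)c2)c1` gives 2400 nM

Compound 3 holds the lowest of the three numbers, but only nominally: the steps are a 1.0-fold lower number from compound 1 to compound 3 (0.02 log units; within the scatter) and a 1.1-fold lower number from compound 2 to compound 3 (0.05 log units; within the scatter), both within the scatter, so the three compounds cannot be ranked against each other.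

Compound 4 `O=S(=O)(NCCCNCc1ccc(Cl)cc1)c1cc(C(F)(F)F)cc(C(F)(F)F)c1` is the next member. Its difference from compound 3 is 4-chlorophenyl in place of 3-methoxyphenyl on a saturated chain carbon bound to an amine nitrogen. The steps already seen at this position all bear on it: a 1.1-fold higher number from compound 1 to compound 2 (0.03 log units; within the scatter), a 1.0-fold lower number from compound 1 to compound 3 (0.02 log units; within the scatter) and a 1.1-fold lower number from compound 2 to compound 3 (0.05 log units; within the scatter). Each exchange of the aryl group on the saturated chain carbon bound to the amine nitrogen left the number unmoved beyond the scatter, including the move from a chlorinated ring to a methoxy ring. Nothing in the set points to the 4-chlorophenyl group behaving differently, so no step beyond the scatter is expected in this assay.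

Compound 4 is therefore estimated at 2500 nM, with a range of 1300 nM to 5000 nM, the expected step being a 1.0-fold higher number from compound 3 to compound 4 (0.02 log units; within the scatter).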

Compound 4, concentration for 50% growth inhibition: 2800 nM
Compound 4: the middle estimate sits 1.1-fold (0.05 log units) below what was measured; measured number inside the range.
By their numbers in this assay, from the lowest: compounds 3, 1, 2 and 4 (each within the scatter of the next).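

In this assay, 4-chlorophenyl carries no hydrogen-bond acceptor where 3-methoxyphenyl carries one, yet the step is only a 1.2-fold higher number from compound 3 to compound 4 (0.07 log units; within the scatter), so this change in acceptor count on the saturated chain carbon bound to the amine nitrogen leaves the number within the scatter. Among the compounds shown here, compound 4 also adds the first exchange of a single ring substituent, hydrogen in place of chloro on an aromatic carbon, with a 1.1-fold higher number from compound 1 to compound 4 (0.05 log units; within the scatter), and the exchange for 2,3-dihydro-1,4-benzodioxin-2-yl gives a 1.0-fold higher number from compound 2 to compound 4 (0.02 log units; within the scatter), so all four compounds remain unranked. No supporting measurement bears on this flat result.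

The compounds shown leave open whether this tolerance extends beyond neutral aryl groups, for example to a ring bearing a carboxylic acid or a primary amine. They also leave open whether a longer chain in place of the shared one would move the number beyond the scatter.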